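This account rests on a few compounds, and the source may have more. Where it says the series, first, only, none or still open, it means among the compounds named here.

Measured compounds:

Compound 1, `CC1C(=O)CC(c2ccc(Cl)cc2)N(C(=O)CN2CCN(C)CC2)C1c1ccc(N(C)C)cc1` — in a functional assay on the whole organism for inhibition, with Mus musculus as the target, in the writhing test, with a stated time of 1 h, at a dose of 60 mg/kg by the oral route (a lower number here means less inhibition, a higher number more inhibition at the dose given (going by the name of the read-out)), compound 1 gives 28.1%.
Compound 2, `COc1ccc(C2C(C)C(=O)CC(c3ccc(Cl)cc3)N2C(=O)CN2CCN(C)CC2)cc1` — in this assay compound 2 gives 53.1%.
Compound 3, `CC1C(=O)CC(c2ccc(Cl)cc2)N(C(=O)CCl)C1c1ccc(N(C)C)cc1` — in this assay compound 3 gives 17.8%.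

All three share one core and differ in two places. Compound 1 becomes compound 2 by a change on an aromatic ring: methoxy in place of dimethylamino on an aromatic carbon. This change brought a number 25 percentage points higher from compound 1 to compound 2 (beyond the scatter). Compound 1 becomes compound 3 by a change at the other end of the molecule: chloro in place of 4-methylpiperazin-1-yl on a saturated chain carbon bound to a carbonyl carbon. This change brought a number 10.3 percentage points lower from compound 1 to compound 3 (beyond the scatter), so that compound 3 stands lowest of the three measured compounds.

Compound 4, `COc1ccc(C2C(C)C(=O)CC(c3ccc(Cl)cc3)N2C(=O)CCl)cc1`, has not yet been measured in this assay. It stands to compound 3 as compound 2 stands to compound 1: methoxy in place of dimethylamino on an aromatic carbon. The place of this change is described in the same words for both pairs, so it is the same change, made here on the core of compound 3 rather than the core of compound 1; how those two cores differ is told above by the change from compound 1 to compound 3.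

The change from compound 1 to compound 2 has been made once and seen once, so the expectation for compound 4 rests on that single step. Compound 4 is expected to rise from compound 3 by a number 22.2 percentage points higher from compound 3 to compound 4 (beyond the scatter), a step somewhat smaller than a number 25 percentage points higher from compound 1 to compound 2 (beyond the scatter), with a wider range, since the change has not been tested on the core of compound 3. For compound 4 the estimated value in this assay is 40%, expected to lie between 25% and 56%.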

Compound 4, a percentage reported as inhibition, in the whole organism at one dose (the size of the read-out at that dose, not a potency) in the Mus musculus assay: 44.1%
Beside the measured number, compound 4's estimate is 4.1 percentage points below it; low and high end bracket the measured number.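

In the Mus musculus assay, methoxy in place of dimethylamino on the aromatic ring gave a number 26.3 percentage points higher from compound 3 to compound 4 (beyond the scatter), and this step closely matches the one seen on the other core: the same change on two cores in the Mus musculus assay, a number 25 percentage points higher (beyond the scatter) from compound 1 to compound 2 and a number 26.3 percentage points higher (beyond the scatter) from compound 3 to compound 4, 1.3 percentage points apart, within the scatter of two such steps

In the Mus musculus assay, chloro in place of 4-methylpiperazin-1-yl gave a number 9 percentage points lower from compound 2 to compound 4 (within the scatter), and this change also looks much the same on both cores: the same change on two cores in the Mus musculus assay, a number 10.3 percentage points lower (beyond the scatter) from compound 1 to compound 3 and a number 9 percentage points lower (within the scatter) from compound 2 to compound 4, 1.3 percentage points apart, within the scatter of two such steps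

So across these four compounds, each change shifted the inhibition by a similar amount whichever group stood at the other place, but two cores are too few to show that this would hold on any other core, and in a physicochemical assay for lipophilicity, using the shake flask method (a higher number here means a more lipophilic compound, a lower number a more polar compound), compound 3 gives 1.24 and compound 4 gives 1.29, two values within the scatter of each other.

The compounds shown leave open whether other groups would follow the same pattern, such as a hydroxy or a fluoro in place of methoxy on the aromatic ring, or a morpholin-4-yl or a longer chain in place of the chloro or 4-methylpiperazin-1-yl end. They also leave open how these steps would look at other doses, since each number here is the size of the effect at a single dose and not a potency.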